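Series notes: a larger group on the ring oxygen

The compounds below may be only part of what the source reports. "The series", "measured", "known", "first", "only" and "open" are said of these compounds alone.

compound 1 `CCOC(=O)c1c(C)nc(-c2cccc(C#N)c2)n1OC`: 9130 nM
compound 2 `CCOC(=O)c1c(C)nc(-c2cccc(C#N)c2)n1OC(C)C`: 6740 nM

In a functional assay on a cell-free system (plasma, Oryctolagus cuniculus) for inhibition, with stated times of 5 min, 1 min and 6 min (on this read-out higher numbers stand for weaker inhibition and lower numbers for stronger inhibition), compound 2 and compound 1 sit within the scatter of each other, so no order between them is claimed. Compound 3 `CCOC(=O)c1c(C)nc(-c2cccc(C#N)c2)n1OCc1ccc(F)cc1` is not yet measured. It differs from compound 2 by 4-fluorobenzyl in place of isopropyl on an oxygen on an aromatic ring. Among the measured compounds shown here, the one measured step at this place is a 1.4-fold lower number from compound 1 to compound 2 (0.13 log units; within the scatter), which stayed within the scatter. Since nothing beyond that is known for this position, only a modest lowering of the number is expected for compound 3, a 1.7-fold lower number from compound 2 to compound 3 (0.23 log units; within the scatter). The estimate for compound 3 is 4000 nM, with a range from 1200 nM to 13000 nM.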

Compound 3, half-maximal inhibitory concentration: 5880 nM
Compound 3: middle estimate off by 1.5-fold (0.17 log units), on the low side; low and high end bracket the measured number.
By their numbers in this assay, from the lowest: compounds 3, 2 and 1 (each within the scatter of the next).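

In this assay, the exchange of isopropyl for 4-fluorobenzyl gives a 1.1-fold lower number from compound 2 to compound 3 (0.06 log units; within the scatter), and the wider comparison with the methyl compound gives a 1.6-fold lower number from compound 1 to compound 3 (0.19 log units; within the scatter). The ring oxygen therefore carries a group with a six-membered aromatic ring, not only small alkyl groups, and all three numbers remain within the scatter along both steps. No available evidence bears on this result.

Still open, going by these compounds, is whether an amine, a carboxylic acid or a longer chain on the ring oxygen would give a step beyond the scatter. The compounds shown also leave open what the fluorine contributes, as no unsubstituted benzyl group appears among them.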